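This account rests on a few compounds, and the source may have more. Where it says the series, first, only, none or still open, it means among the compounds named here.

Measured in a functional assay on the whole organism with Rattus norvegicus as the target; a higher number here means that more compound is needed for the effect, a lower number that less compound is needed:
- compound 1 `CCOCCOC(=O)C(=O)Nc1nc(-c2cc(Br)no2)cs1`: 11 mg/kg
- compound 2 `COCCOC(=O)C(=O)Nc1nc(-c2cc(Br)no2)cs1`: 7 mg/kg
- compound 3 `CCOC(=O)C(=O)Nc1nc(-c2cc(C)no2)cs1`: 0.2 mg/kg

Compound 1 shares the high end of these values with compound 2, while compound 3 lies far lower. Compound 4 `CCOCCOC(=O)C(=O)Nc1nc(-c2cc(-c3c(F)cccc3Cl)no2)cs1` keeps the chain of compound 1 and changes one group: 2-chloro-6-fluorophenyl in place of bromo on an aromatic carbon. In short, 2-chloro-6-fluorophenyl replaces bromo on an aromatic carbon.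

Among the compounds with values here, the only measured step, a 1.6-fold lower number from compound 1 to compound 2 (0.20 log units; within the scatter), lies in the saturated chain and not at this carbon, so it says little about the new group. The chain and the group on that carbon both differ between compound 1 and compound 3, so the low value of compound 3 cannot be credited to either difference. No measurement covers this swap directly. Within the data shown here, compound 3 at 0.2 mg/kg shows only that much lower numbers occur in this small set, so a modest move toward a lower number is expected, with wide uncertainty.

The expected change is a 1.8-fold lower number from compound 1 to compound 4 (0.26 log units; within the scatter). For compound 4 the estimated value is 6 mg/kg, with an expected range of 1 mg/kg to 30 mg/kg.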

Compound 4, dose for half-maximal effect: 1.1 mg/kg
The estimate for compound 4 lay 5.5-fold (0.74 log units) above the measured number; the measured number falls inside the stated range.
By their numbers in this assay, from the lowest: compound 3; then compound 4; then compounds 2 and 1 (each within the scatter of the next).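

In this assay, putting 2-chloro-6-fluorophenyl in place of bromo on the aromatic carbon next to the ring nitrogen gives a 10-fold lower number from compound 1 to compound 4 (1.00 log units; beyond the scatter) and this step lies beyond the scatter. Within the data shown here, the earlier compounds held no step at this carbon, so this is the first sign that the position tolerates a group of 8 heavy atoms and a six-membered aromatic ring where bromo had 1 heavy atom, and that less compound is then needed for the effect. Nothing measured here explains why the number falls.

The compounds shown leave open whether the chlorine and fluorine matter, or whether a plain phenyl or a small amine on this carbon would do the same. Compound 3 differs from compound 4 in more than one place, so how the chain and the group on this carbon combine also remains unresolved.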